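A few compounds are considered here, and "the series" means these few. Any claim that something is new, unique, unknown or untested is made for them only; others in the source may bear on it.

Series against a functional assay on cells (Splenocyte, Mus musculus, strain BALB/c) for inhibition, read by scintillation counting and thymidine incorporation, with a stated time of 72 h; a higher number here means a weaker inhibitor, a lower number a stronger inhibitor:

Compound 1, `COc1ccc(C(=O)N/N=C(C)/C=N/Nc2ccc([N+](=O)[O-])cc2)cc1`. In this assay compound 1 gives only a limit, > 12000 nM.
Compound 2, `CC(/C=N/Nc1ccc([N+](=O)[O-])cc1)=N\NC(=O)c1ccccc1N`. In this assay compound 2 gives 4900 nM.
Compound 3, `CC(/C=N/Nc1ccc([N+](=O)[O-])cc1)=N\NC(=O)c1ccccc1Oc1ccccc1`. In this assay compound 3 gives only a limit, > 12000 nM.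

Compound 2 is the only member with a number; the other two values are limits, as shown by the limit of > 12000 nM in this assay, at which 2 of the 3 values shown sit. Compound 4, `CC(/C=N/Nc1ccc([N+](=O)[O-])cc1)=N\NC(=O)c1ccc(N(C)C)cc1`, has not been measured. It differs from compound 2 as follows: 4-(dimethylamino)phenyl in place of 2-aminophenyl on a carbonyl carbon. Within the data shown here, two measured steps touch the same carbonyl-bound aryl: an at least 2.4-fold lower number from compound 1 to compound 2 (0.38 log units; beyond the scatter) and an at least 2.4-fold higher number from compound 2 to compound 3 (0.38 log units; beyond the scatter). Both read the same way: compound 2, carrying the 2-aminophenyl, is the only one accompanied by a measurable value, while the 4-methoxyphenyl of compound 1 and the phenoxy-bearing aryl of compound 3 each sit at the limit. Among the measured compounds shown here, exchanging 2-aminophenyl for 4-(dimethylamino)phenyl removes the one group that went with a number, so a rise of at least modest size is expected, most likely back to the limit. For compound 4 the expected value is 12000 nM, with a range from 5000 nM to 30000 nM. The step expected from this change is a 2.4-fold higher number from compound 2 to compound 4 (0.39 log units; beyond the scatter).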

Compound 4, half-maximal inhibitory concentration: > 12000 nM
Compound 4: only a limit was reported; the forecaster's own chance of this, stated with the estimate: 60%; the middle value lies on the limit itself.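

The exchange of 2-aminophenyl for 4-(dimethylamino)phenyl on the carbonyl carbon gives an at least 2.4-fold higher number from compound 2 to compound 4 (0.38 log units; beyond the scatter) in this assay. A nitrogen-bearing aryl at this place therefore does not by itself keep a measurable value, which compound 1 and compound 3, with no nitrogen on that aryl, could not show. The step from compound 1 to compound 4 joins two limits and cannot be read, and compound 2 stays the only member with a number: the limit of > 12000 nM in this assay, at which 3 of the 4 values shown sit.

Which feature of 2-aminophenyl goes with that number stays open, as 2-aminophenyl and 4-(dimethylamino)phenyl differ both in hydrogen-bond donor count and in the form and place of the nitrogen group. Also open, on these data alone, is whether a hydroxyl or a carboxylic acid in place of the amino group of compound 2 would keep a number.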